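An Octyl Extension on a Long Chain: Expected Cytotoxicity

The source may report more compounds than this note shows. Statements on the series, on what has been measured and on what is new or still open speak of the compounds shown alone.

Four compounds share a core in which a single carbon carries three short arms, each ending in a carboxylic acid, and is attached through nitrogen to a long saturated chain. Compound 1 `CCCCCCCCCCCCCC(=O)NC(CCC(=O)O)(CCC(=O)O)CCC(=O)O` links that chain through an amide. In an ADME assay on cells (Epithelial cell, Homo sapiens) for cytotoxicity, read by MTT assay (a lower number here means that less compound is needed, a higher number that more compound is needed for the effect), compound 1 gives 300000 nM. Compound 2 `CCCCCCCCCCCCCCCCCCCCCC(=O)NC(CCC(=O)O)(CCC(=O)O)CCC(=O)O` differs from compound 1 by octyl in place of hydrogen on a saturated chain carbon, ten or more bonds along the chain from a carbonyl carbon, and in this assay compound 2 gives 250000 nM. The step of a 1.2-fold lower number from compound 1 to compound 2 (0.08 log units; within the scatter) is therefore small, and the two values cannot be told apart.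

Compound 3 `CCCCCCCCCCCCCCNC(=O)NC(CCC(=O)O)(CCC(=O)O)CCC(=O)O` links the chain through a urea instead; in this assay compound 3 gives "not determined" (no result reported), so no number stands for it, and the difference between the core of compound 3 and the core of compound 1 is not broken down here. Compound 4 `CCCCCCCCCCCCCCCCCCCCCCNC(=O)NC(CCC(=O)O)(CCC(=O)O)CCC(=O)O` differs from compound 3 by octyl in place of hydrogen on a saturated chain carbon, ten or more bonds along the chain from an amide-type nitrogen. This is the same kind of change as that from compound 1 to compound 2, though the two places are not described in the same words: there the position is counted from a carbonyl carbon, here from an amide-type nitrogen.

Because the step of a 1.2-fold lower number from compound 1 to compound 2 (0.08 log units; within the scatter) lies within the scatter, compound 4 is expected to land near compound 1 and compound 2. For compound 4 the expected value in this assay is 270000 nM, most likely between 110000 nM and 650000 nM.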

Compound 4, half-maximal effective concentration: 260000 nM
Compound 4: the middle estimate sits 1.0-fold (0.02 log units) above what was measured, and the stated range covers the measured number.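

Compound 3 has no reported result in this assay, so the octyl step from compound 3 to compound 4 cannot be read, even with compound 4 at 260000 nM. The compounds shown leave open whether the octyl extension has the same small size on the urea-linked chain as on the amide-linked chain. Nothing measured here offers an explanation for these values.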